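The source may hold more compounds than are shown below. What is called first, only, known or untested is meant among the compounds shown, and "the series" means these compounds.

Measured in a functional assay on MCF7 cells (Homo sapiens) for cytotoxicity, read by MTT assay, with a stated time of 48 h (on this read-out higher numbers stand for weaker inhibition and lower numbers for stronger inhibition), so far
compound 1 `C/C(=N\NC(=S)Nc1ccccc1I)c1ccccn1` gives 4.1 nM
compound 2 `CC(=NNC(=S)Nc1ccccc1[N+](=O)[O-])c1ccccn1` gives 5.7 nM
compound 3 `CC(=NNC(=S)Nc1ccccc1)c1ccccn1` gives 0.18 nM

Compound 3 has the lowest number of the three, and its gaps to the other two lie beyond the scatter. The next step leads to compound 4 `CC(=NNC(=S)Nc1ccccc1I)c1ccccn1` and puts iodo in place of hydrogen on an aromatic carbon, ortho to a large group, a change counted as iodo in place of hydrogen on an aromatic carbon and still unmeasured. Among the compounds with values here, one measured step bears on it. Hydrogen in place of nitro gave a 32-fold lower number from compound 2 to compound 3 (1.50 log units; beyond the scatter) as a large change, and read in reverse it points to a higher number when hydrogen gives way to a group. Compound 1, which also carries iodo, gives 4.1 nM and so stands well above compound 3 on these numbers. A large upward step, beyond the scatter, is therefore expected in this assay for this change. The estimated change is a 22-fold higher number from compound 3 to compound 4 (1.35 log units; beyond the scatter) as the expected outcome. Compound 4 is expected at 4 nM with an estimated range from 1.5 nM to 11 nM in this read-out.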

Compound 4, half-maximal inhibitory concentration: 4.1 nM
Compound 4: middle estimate off by 1.0-fold (0.01 log units), on the low side, and the stated range covers the measured number.
By their numbers in this assay, from the lowest: compound 3; then compounds 1, 4 and 2 (each within the scatter of the next).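

In this assay, the aromatic carbon ortho to a large group now has a direct step from hydrogen to iodo, a 23-fold higher number from compound 3 to compound 4 (1.36 log units; beyond the scatter), so the rise seen with nitro is not confined to that one group. The two groups themselves cannot be told apart at this place, a 1.4-fold lower number from compound 2 to compound 4 (0.14 log units; within the scatter), and both stand well above compound 3, which carries hydrogen there. One further pair adds no structural step, no change at the digits printed from compound 1 to compound 4 (within the scatter), and the only difference between its members lies in how they are drawn: the fact that one of compounds 1 and 4 is drawn with a defined configuration and the other without, at the place where they differ

The compounds shown leave open how fluoro, methyl or an amine at this place would compare with hydrogen. They also leave open whether iodo on another carbon of the same ring would give a step of similar size.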